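The compounds below may be only part of what the source reports. "The series", "measured", "known", "first", "only" and "open" are said of these compounds alone.

Series notes: two measured compounds share the core of compound 1 `O=C(/C=C\c1ccccc1O)N1N=C(c2ccncc2)OC1c1c[nH]c2ccccc12` and differ only in the aryl ring on the double-bonded chain. In an ADME assay on HeLa cells (Homo sapiens) for cytotoxicity, read by MTT assay, with a stated time of 72 h (on this read-out lower numbers stand for stronger inhibition of growth and higher numbers for weaker inhibition of growth), compound 1 gives 26.8 ug/mL. Compound 2 `O=C(/C=C\c1cccc(Cl)c1)N1N=C(c2ccncc2)OC1c1c[nH]c2ccccc12` carries a 3-chlorophenyl in place of the 2-hydroxyphenyl. In this assay compound 2 returns only a limit, > 30 ug/mL, so no number is known for it. The record here shows (the limit of > 30 ug/mL in this assay, at which 1 of the 2 values shown sits). Among the compounds with values here, the one measured step, an at least 1.1-fold higher number from compound 1 to compound 2 (0.04 log units; that floor lies within the scatter), therefore has only a floor, and that floor lies within the usual scatter. Compound 3 `O=C(/C=C\c1cccc(Cl)c1Cl)N1N=C(c2ccncc2)OC1c1c[nH]c2ccccc12` follows from compound 2 by chloro in place of hydrogen on an aromatic carbon. Within the data shown here, only the step from compound 1 to compound 2 bears on this, and it shows nothing beyond the scatter; for a second chloro on the same ring no step has been measured at all. No step beyond the scatter is therefore expected in this assay, and compound 3 is expected to sit near the limit, with a step of a number no higher from compound 2 to compound 3 (the limit leaves the size open). Compound 3 is estimated at 30 ug/mL, ranging from 15 ug/mL to 60 ug/mL, and a limit-only result is a real possibility.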

Compound 3, concentration for 50% growth inhibition: > 30 ug/mL
Compound 3 ended at the assay's limit; the forecaster's own chance of this, stated with the estimate: 55%; the middle value lies on the limit itself.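

In this assay compound 3, with a second chloro ortho to a chloro group on the aromatic ring, still gives only a limit, > 30 ug/mL, so this added chloro does not bring a number into the measurable range. The step between compound 2 and compound 3 cannot be read, and the two chlorinated rings remain unseparated at this position: the limit of > 30 ug/mL in this assay, at which 2 of the 3 values shown sit. The 2,3-dichlorophenyl in place of the 2-hydroxyphenyl gives an at least 1.1-fold higher number from compound 1 to compound 3 (0.04 log units; that floor lies within the scatter), which adds a second floor of the same size to the one for the 3-chlorophenyl and still shows no change beyond the scatter.

Open, as far as these compounds go, is how far the true values of compound 2 and compound 3 lie from the limit, and so whether the second chloro has any effect in this assay. Also open, from the compounds shown here alone, is whether an amine, a carboxylic acid or a methoxy group on this aromatic ring would give a number clearly separated from the limit.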